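Swapping a Sulfonyl Methyl Arm for a Dimethylsulfamoyl Group

This account rests on a few compounds, and the source may have more. Where it says the series, first, only, none or still open, it means among the compounds named here.

Three measured compounds share a core in which a chloro-substituted phenoxyacetic acid is linked by an alkyne to a second benzene ring. Compound 1 `CS(=O)(=O)Cc1cccc(C#Cc2cc(Cl)ccc2OCC(=O)O)c1` gives 48 nM in an assay on CHO cells for displacement of a labelled ligand from prostaglandin D2 receptor 2 (Homo sapiens), read by scintillation counting (a lower number here means a stronger inhibitor, a higher number a weaker inhibitor), the second highest of the three numbers. Compound 3 `CCCS(=O)(=O)c1cccc(C#Cc2c(OCC(=O)O)cccc2-c2sc(C)nc2C)c1` gives 54 nM, within the scatter of compound 1. Compound 2 `COCCN(C)S(=O)(=O)c1ccc(C)c(C#Cc2cc(Cl)ccc2OCC(=O)O)c1` gives 4.1 nM, clearly lower than compound 1, and its structure also carries a nitrogen bound to the sulfonyl sulfur.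

Compound 4 `CN(C)S(=O)(=O)c1cccc(C#Cc2cc(Cl)ccc2OCC(=O)O)c1` has not yet been measured. Relative to compound 1 the change is dimethylsulfamoyl in place of (methylsulfonyl)methyl on an aromatic carbon. Because compound 2 reaches 4.1 nM with a related nitrogen-bearing sulfonyl group, a modest improvement is expected, though compound 2 also differs elsewhere, so the step is uncertain. The expected step is a 2.4-fold lower number from compound 1 to compound 4 (0.38 log units; beyond the scatter). Compound 4 is therefore estimated to give 20 nM in this assay, with a likely range from 6 nM to 60 nM.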

Compound 4, inhibition constant: 14 nM
Estimate against measurement, compound 4: 1.4-fold (0.15 log units) above; the measured number falls inside the stated range.
By their numbers in this assay, from the lowest: compound 2; then compound 4; then compounds 1 and 3 (each within the scatter of the next).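

Placing dimethylsulfamoyl instead of (methylsulfonyl)methyl on this aromatic carbon, meta to a large group, gives a 3.4-fold lower number from compound 1 to compound 4 (0.54 log units; beyond the scatter) in this assay. This is the first comparison among these compounds in which only one place changes, so the step belongs to this swap alone and shows that this position responds to the choice of group. The data give no explanation for the size or direction of the step.

Going by these compounds, it remains open whether the result depends on the nitrogen joined to the sulfonyl sulfur or on the two methyl groups it carries, which a sulfonamide with an unsubstituted amino group or a morpholine ring on the sulfonyl group could test. On these data alone, whether the same swap would have a similar effect on the core of compound 3 also remains open.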